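The source may hold more compounds than are shown below. What is called first, only, known or untested is meant among the compounds shown, and "the series" means these compounds.

Two compounds sharing one core, which differ only in the group attached to the carbon that carries a double bond to nitrogen, have been measured in an assay on CHO-K1 cells for displacement of a labelled ligand from adenosine receptor A1 (Homo sapiens), read by scintillation counting, with a stated time of 60 min; on this read-out lower numbers stand for stronger inhibition and higher numbers for weaker inhibition. Compound 1 `Nc1nc(N/N=C/c2ccc(-c3ccc(Br)cc3)o2)nc2c1ncn2[C@@H]1O[C@H](CO)[C@@H](O)[C@H]1O` gives 4.5 nM. Compound 2 `Nc1nc(N/N=C/c2ccc[nH]2)nc2c1ncn2[C@@H]1O[C@H](CO)[C@@H](O)[C@H]1O` gives 8 nM, and the two numbers lie within the usual scatter of each other, so neither can be called the tighter binder on this evidence.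

Compound 3 `CCOc1cc(/C=N/Nc2nc(N)c3ncn([C@@H]4O[C@H](CO)[C@@H](O)[C@H]4O)c3n2)ccc1O` has not yet been measured in this assay. It differs from compound 2 in one place: 3-ethoxy-4-hydroxyphenyl in place of 1H-pyrrol-2-yl on a carbon with a double bond to nitrogen.

Going by the values given here, no measured pair shows a step of this kind, so the two values known offer only a rough guide. Both show that varied groups in this position keep the number low, and an expected step of a 1.9-fold higher number from compound 2 to compound 3 (0.27 log units; within the scatter) toward a somewhat higher number, possibly none beyond the scatter, seems reasonable. Compound 3 is therefore estimated at 15 nM, within a range from 3 nM to 80 nM.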

Compound 3, inhibition constant: 6940 nM
Estimate against measurement, compound 3: 460-fold (2.67 log units) below; the whole stated range lies below it.
By their numbers in this assay, from the lowest: compounds 1 and 2 (each within the scatter of the next); then compound 3.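

In this assay this position proves far less tolerant than compounds 1 and 2 suggested: putting 3-ethoxy-4-hydroxyphenyl in place of 1H-pyrrol-2-yl on the carbon with a double bond to nitrogen gives an 870-fold higher number from compound 2 to compound 3 (2.94 log units; beyond the scatter), a large step well beyond the scatter. So a low number here is not a general feature of the shared core, and the group on this carbon can decide between strong and weak inhibition. No measurement at hand gives a reason for the loss.

The change replaces the ring and introduces the ethoxy and hydroxy groups all at once, so the compounds shown cannot tell which of these parts matters. On these data alone, it remains open how an unsubstituted phenyl, or a phenyl carrying only a hydroxy or only an ethoxy group, would behave here.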